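The compounds below may be only part of what the source reports. "The series", "measured", "known", "first", "only" and "open" are said of these compounds alone.

Compound 1 `CCCCCCCCCNC[C@@H]1OC[C@H](N)[C@H]1O` opens the set examined in a functional assay on A549 cells (Homo sapiens) for antiproliferative activity, read by MTT assay, with a stated time of 72 h; on this read-out lower numbers stand for stronger inhibition and higher numbers for weaker inhibition. In this assay compound 1 reaches only a limit, > 128000 nM. Compound 2 `CCCCCCCCCCCCCCNC[C@@H]1OC[C@H](N)[C@H]1O` carries pentyl in place of hydrogen on a saturated chain carbon, nine bonds along the chain from an amine nitrogen; in this assay compound 2 gives 20000 nM, and the step is an at least 6.4-fold lower number from compound 1 to compound 2 (0.80 log units; beyond the scatter). The second pair rests on compound 3 `CCCCCCCCCNC[C@@H]1OC[C@H](N)[C@@H]1O`, whose core differs from that of compound 1 in that (the two compounds have the same atoms and bonds and differ only in configuration as drawn: 1 of 3 stereo elements differ; a stereocentre at a saturated ring carbon is drawn R in compound 1 and S in compound 3); in this assay compound 3 gives 22100 nM, and the step is an at least 5.7-fold lower number from compound 1 to compound 3 (0.76 log units; beyond the scatter). The values of compound 2 and compound 3 lie within the usual scatter of each other. Compound 4 `CCCCCCCCCCCCCCNC[C@@H]1OC[C@H](N)[C@@H]1O` has not been measured; against compound 3 it carries pentyl in place of hydrogen on a saturated chain carbon, nine bonds along the chain from an amine nitrogen, the same change that turned compound 1 into compound 2, made twice in all among these compounds. The earlier step can only be given as a floor, since compound 1 stands at a limit (the limit of > 128000 nM in this assay, at which 1 of the 3 values shown sits). From compound 3 to compound 4 the step is expected to be a 4.4-fold lower number from compound 3 to compound 4 (0.65 log units; beyond the scatter), resting on an at least 6.4-fold lower number from compound 1 to compound 2 (0.80 log units; beyond the scatter) and on the value of compound 3, 22100 nM. Compound 4 is therefore estimated at 5000 nM, between 1500 nM and 20000 nM.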

Compound 4, half-maximal inhibitory concentration: 2850 nM
Compound 4: middle estimate off by 1.8-fold (0.24 log units), on the high side; low and high end bracket the measured number.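

In this assay the pentyl change carries over to the second core, with a 7.8-fold lower number from compound 3 to compound 4 (0.89 log units; beyond the scatter), and it can be set beside the same change on the first core: the same change on two cores in this assay, an at least 6.4-fold lower number (0.80 log units; beyond the scatter) from compound 1 to compound 2 and a 7.8-fold lower number (0.89 log units; beyond the scatter) from compound 3 to compound 4; the limit leaves it open whether they differ. Compound 1 stands at a limit, so the earlier step is only a floor, and the two cores share a direction without showing that the size of the step is the same: the limit of > 128000 nM in this assay, at which 1 of the 4 values shown sits. The change in configuration points the same way with the longer chain, at a 7.0-fold lower number from compound 2 to compound 4 (0.85 log units; beyond the scatter), but these two cores alone show nothing about how the pentyl change would behave on any other core: the fact that compounds 2 and 4 differ only in the configuration as drawn.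

The compounds shown leave open whether a longer chain would continue this direction, or whether it would hold for a chain ending in an amine or a carboxylic acid. They also leave open how the other two stereo elements bear on the result, since only one of them varies here.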